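Compound 3 and Its 2,4-Difluorophenyl Counterpart, Compound 4

The compounds below may be only part of what the source reports. "The series", "measured", "known", "first", "only" and "open" are said of these compounds alone.

In a functional assay on MDA-MB-231 cells (Homo sapiens) for antiproliferative activity, read by MTT assay, with a stated time of 48 h (a lower number here means a stronger inhibitor, a higher number a weaker inhibitor), compound 1 `C=CS(=O)(=O)N1CCN(c2ncnc3sc(-c4ccc(N5CCN(C)CC5)cc4)cc23)CC1` gives 7550 nM and compound 2 `CCS(=O)(=O)N1CCN(c2ncnc3sc(-c4ccc(N5CCN(C)CC5)cc4)cc23)CC1` gives 7330 nM. Compound 3 `CN1CCN(c2ccc(-c3cc4c(N5CCN(C(=O)Nc6ccc(OC(F)(F)F)cc6)CC5)ncnc4s3)cc2)CC1` gives 4600 nM, a value within the scatter of both others, so the three cannot be ranked. For the measured compounds named here, the only measured step, a 1.0-fold lower number from compound 1 to compound 2 (0.01 log units; within the scatter), is ethyl in place of vinyl on a sulfonyl sulfur, and it lies within the scatter.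

Compound 4 `CN1CCN(c2ccc(-c3cc4c(N5CCN(C(=O)Nc6ccc(F)cc6F)CC5)ncnc4s3)cc2)CC1` differs from compound 3 in one place: 2,4-difluorophenyl in place of 4-(trifluoromethoxy)phenyl on an amide-type nitrogen. In words, 2,4-difluorophenyl stands in place of 4-(trifluoromethoxy)phenyl on an amide-type nitrogen. Going by the values given here, the measured step concerns a different group, and no measured pair changes the group on this nitrogen, so the data offer no direct guide to this change. Among the compounds with values here, they show only that all three values so far fall within the scatter of one another, despite the differing groups on the shared core. No step beyond the scatter is therefore expected in this assay, although the range must stay wide. The expected step is a 1.0-fold lower number from compound 3 to compound 4 (0.01 log units; within the scatter). Compound 4 is estimated at 4500 nM, with an expected range from 1800 nM to 10000 nM.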

Compound 4, half-maximal inhibitory concentration: 11400 nM
For compound 4 the middle estimate is 2.5-fold (0.40 log units) below the measured one; the measured number lies above the stated range.
By their numbers in this assay, from the lowest: compounds 3, 2, 1 and 4 (each within the scatter of the next, the first and the last beyond it).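

In this assay, for the compounds shown here, the group on the amide-type nitrogen gives the first step beyond the scatter: a 2.5-fold higher number from compound 3 to compound 4 (0.39 log units; beyond the scatter) is modest, but it shows that this position can register a change of aryl group, which the earlier compounds could not show. The same compound 4 does not separate from the sulfonyl compounds, since both a 1.6-fold higher number from compound 2 to compound 4 (0.19 log units; within the scatter) and a 1.5-fold higher number from compound 1 to compound 4 (0.18 log units; within the scatter) stay within the scatter, so exchanging the sulfonyl groups for (2,4-difluorophenyl)carbamoyl on the amine nitrogen in a ring has no readable effect here. Going by these compounds alone, the urea-type link alone therefore does not set these values apart, and only the pair of aryl groups does, with all four numbers still in the micromolar range. No measurement shown here accounts for the step.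

The compounds shown leave open whether the step follows from the departure of the trifluoromethoxy group or from the arrival of the two fluorines, as unsubstituted phenyl on this nitrogen would be needed to tell these apart. They also leave open how a phenyl bearing an amine or a carboxylic acid would read at this position.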